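A few compounds are considered here, and "the series" means these few. Any claim that something is new, unique, unknown or untested is made for them only; others in the source may bear on it.

Working notes on the series. In a functional assay on HepG2 cells (Homo sapiens) for inhibition, read by MTT assay, with a stated time of 72 h (on this read-out higher numbers stand for weaker inhibition and lower numbers for stronger inhibition), compound 1 (`COc1ccc(-c2nnc(SCCCN3CCN(c4nc5ccccc5s4)CC3)o2)cc1`) gives 134000 nM, compound 2 (`Fc1ccc(-c2nnc(SCCCN3CCN(c4nc5ccccc5s4)CC3)o2)cc1`) gives 234000 nM and compound 3 (`CC(C)(C)Oc1ccc(-c2nnc(SCCCN3CCN(c4nc5ccccc5s4)CC3)o2)cc1`) gives 202000 nM. Compound 3 cannot be separated from the other two, as the steps to it show: a 1.2-fold lower number from compound 2 to compound 3 (0.06 log units; within the scatter) and a 1.5-fold higher number from compound 1 to compound 3 (0.18 log units; within the scatter).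

The next change leads to compound 4 (`c1ccc(-c2nnc(SCCCN3CCN(c4nc5ccccc5s4)CC3)o2)cc1`): hydrogen in place of tert-butoxy on an aromatic carbon. This is hydrogen in place of tert-butoxy on an aromatic carbon, or 4-(tert-butoxy)phenyl to phenyl.

All three measured steps exchange the group on this same aromatic carbon, so they bear directly on the change. The third, a 1.7-fold higher number from compound 1 to compound 2 (0.24 log units; within the scatter), also stays within the scatter. Going by the values given here, no measured compound carries hydrogen there, so this exact exchange has no direct precedent.

No shift beyond the scatter is therefore expected in this assay, and no direction can be assigned. The estimated step is a 1.1-fold lower number from compound 3 to compound 4 (0.03 log units; within the scatter). For compound 4 the expected value is 190000 nM, with an estimated range of 100000 nM to 350000 nM.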

Compound 4, half-maximal inhibitory concentration: 217000 nM
Estimate against measurement, compound 4: 1.1-fold (0.06 log units) below, and the stated range covers the measured number.
By their numbers in this assay, from the lowest: compounds 1, 3, 4 and 2 (each within the scatter of the next).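

Taking the group away altogether, rather than exchanging it, still leaves the number in this assay within the scatter: the step from tert-butoxy reads (a 1.1-fold higher number from compound 3 to compound 4 (0.03 log units; within the scatter)), the step from fluoro reads (a 1.1-fold lower number from compound 2 to compound 4 (0.03 log units; within the scatter)) and the step from methoxy reads (a 1.6-fold higher number from compound 1 to compound 4 (0.21 log units; within the scatter)). Hydrogen, fluoro, methoxy and tert-butoxy on this aromatic carbon therefore cannot be told apart in this read-out, so among these four compounds the result does not depend on which of these groups is present, or on whether one is present at all. Nothing available explains this flat result.

On these data alone, whether an amine or a carboxylic acid on this same carbon would move the number beyond the scatter remains open. Also open, as far as these compounds go, is whether a longer chain there would do so.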